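The compounds below may be only part of what the source reports. "The series", "measured", "known", "first", "only" and "open" are said of these compounds alone.

Compound 1, `O=C(CCCCCCc1ccccc1)c1ncc(-c2ccc([N+](=O)[O-])cc2)o1`: 50 nM in an assay (Rattus norvegicus) for inhibition of Fatty-acid amide hydrolase 1 (Homo sapiens); a lower number here means a stronger inhibitor, a higher number a weaker inhibitor.
Compound 2, `Cc1cccnc1-c1cnc(C(=O)CCCCCCc2ccccc2)o1`: 15 nM in this assay.
Compound 3, `Cc1ccnc(-c2cnc(C(=O)CCCCCCc3ccccc3)o2)c1`: 0.6 nM in this assay.

Compound 3 gives the lowest number of the three in this assay. The nearest is compound 2, separated by a 25-fold lower number from compound 2 to compound 3 (1.40 log units; beyond the scatter), and the furthest is compound 1, separated by an 83-fold lower number from compound 1 to compound 3 (1.92 log units; beyond the scatter). Both steps lie beyond the scatter, so compound 3 is the strongest inhibitor in this set. The step of a 3.3-fold lower number from compound 1 to compound 2 (0.52 log units; beyond the scatter) is modest.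

Compound 4, `COc1ccnc(-c2cnc(C(=O)CCCCCCc3ccccc3)o2)c1`, differs from compound 3 in one place: methoxy in place of methyl on an aromatic carbon. Among the measured compounds shown here, none of the measured steps makes this change. The two steps from compound 1 replace the whole group on the shared core, and the step from compound 2 to compound 3 concerns only where a methyl sits on the six-membered aromatic ring with 1 nitrogen; none swaps methyl for methoxy. Those steps do show that the number in this assay responds strongly to what sits on that ring, so a change there could matter. For the measured compounds named here, with no direct precedent, the step from compound 3 to compound 4 is expected to be small, a 2.5-fold higher number from compound 3 to compound 4 (0.40 log units; beyond the scatter), leaning toward a higher number. Compound 4 is therefore estimated at 1.5 nM, with a range from 0.3 nM to 8 nM.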

Compound 4, inhibition constant: 0.8 nM
Estimate against measurement, compound 4: 1.9-fold (0.27 log units) above; low and high end bracket the measured number.
By their numbers in this assay, from the lowest: compounds 3 and 4 (each within the scatter of the next); then compound 2; then compound 1.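

Methoxy in place of methyl, on the aromatic carbon opposite the ring nitrogen, gives a 1.3-fold higher number from compound 3 to compound 4 (0.12 log units; within the scatter) in this assay and so compound 3 and compound 4 cannot be told apart here. The earlier compounds shown here showed only that moving a methyl around this ring mattered; this pair shows that a second group, with one more heavy atom and a hydrogen-bond acceptor that methyl lacks, can occupy this place with no change beyond the scatter, and the large gaps to the other compounds remain, with a 19-fold lower number from compound 2 to compound 4 (1.27 log units; beyond the scatter) and a 63-fold lower number from compound 1 to compound 4 (1.80 log units; beyond the scatter) as the two steps. Nothing available explains why methyl and methoxy read alike at this place.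

The compounds shown leave open whether this place accepts groups more generally, as a bare hydrogen, a chlorine, an amine, a carboxylic acid or a longer chain such as butoxy could each test. They also leave open whether 3-methoxypyridin-2-yl would follow 3-methylpyridin-2-yl in compound 2 or read like 4-methoxypyridin-2-yl in compound 4.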